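Shifting the Bromine from Compound 2 to Compound 3

The source may report more compounds than this note shows. Statements on the series, on what has been measured and on what is new or still open speak of the compounds shown alone.

Of the compounds shown here, two sharing one core have been measured in an assay for inhibition of Polyunsaturated fatty acid 5-lipoxygenase (Homo sapiens), read by spectrophotometry, tested at 10 uM, in the presence of a further agent that is not named here; on this read-out higher numbers stand for more inhibition at the one concentration tested (going by the name of the read-out) and lower numbers for less inhibition. Compound 1 `Cc1nc(NC(=O)c2ccccc2)sc1C(=O)/C=C/c1ccccc1` gives 73.5%, and compound 2 `Cc1nc(NC(=O)c2ccccc2)sc1C(=O)/C=C/c1ccc(Br)cc1` gives 52.3%. Within the data shown here, on these two numbers compound 2 stands lowest, with compound 1 as its only and nearest neighbour above it; the single measured step, a number 21.2 percentage points lower from compound 1 to compound 2 (beyond the scatter), shows that bromo in place of hydrogen on an aromatic carbon cost inhibition.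

Compound 3 `Cc1nc(NC(=O)c2ccccc2)sc1C(=O)/C=C/c1cccc(Br)c1` has not yet been measured. It differs from compound 2 by 3-bromophenyl in place of 4-bromophenyl on a double-bonded chain carbon bound to a double-bonded chain carbon. Among the measured compounds shown here, no measured pair shows what moving the bromine from one position to another does: the one step available compares a bromine with a hydrogen, so it bears on this change only indirectly, and both compound 2 and compound 3 carry the bromine. From the compounds shown here alone, the expectation is therefore that compound 3 stays close to compound 2, with a step of a number 2.7 percentage points higher from compound 2 to compound 3 (within the scatter) expected to lie within the scatter, though either direction remains open. Compound 3 is accordingly estimated to give 55% in this assay, with a range from 35% to 75%.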

Compound 3, a percentage reported as inhibition, at one concentration (the size of the read-out at that concentration, not a potency): 42.5%
Compound 3: the middle estimate sits 12.5 percentage points above what was measured, within the range that was stated.
By their numbers in this assay, from the lowest: compounds 3 and 2 (each within the scatter of the next); then compound 1.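

In this assay, 3-bromophenyl in place of 4-bromophenyl on a double-bonded chain carbon bound to a double-bonded chain carbon gives a number 9.8 percentage points lower from compound 2 to compound 3 (within the scatter) and so leaves the two bromine placements unresolved on this read-out. The comparison with compound 1 gives a number 31 percentage points lower from compound 1 to compound 3 (beyond the scatter) and adds something the first bromo step could not show: the loss of inhibition seen with 4-bromophenyl also appears with 3-bromophenyl, so across these three compounds it is not confined to one bromine placement. Nothing available here explains either step.

The compounds shown leave open whether the loss belongs to bromine itself or would also appear with another group on the same phenyl ring, such as fluoro, methoxy, an amine or a carboxylic acid. Since each figure comes from one concentration, they also leave open how compound 1, compound 2 and compound 3 would compare across a range of concentrations, and whether a real difference between the two bromine placements lies hidden within the scatter.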